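The source may hold more compounds than are shown below. What is called first, only, known or untested is meant among the compounds shown, and "the series" means these compounds.

Among the measured compounds shown here, compound 1 `COC(=O)CCNC(=O)[C@H]1CC=C(CCC=C(C)C)C[C@@H]1c1ccccc1` is the one compound here with a full number. In an assay on isolated protein for inhibition of Apoptosis regulator Bcl-2 (Homo sapiens), read by fluorescence polarization, with stated times of 5 min and 10 min (on this read-out lower numbers stand for stronger inhibition and higher numbers for weaker inhibition), compound 1 gives 3100 nM, and that is the only number shown. Compound 2 `CON(C)C(=O)[C@H]1CC2=C(CCCC2(C)C)C[C@@H]1c1ccccc1`, built on a different core, reaches only a limit of the assay rather than a number: in this assay compound 2 gives > 23000 nM. For the measured compounds named here, that limit is the second of the two values shown, (the limit of > 23000 nM in this assay, at which 1 of the 2 values shown sits), so compound 1 stands alone with a measured number and no step between measured compounds can be sized.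

Compound 3 `CC(C)=CCCC1=CC[C@H](C(=O)N(C)C)[C@@H](c2ccccc2)C1` keeps the core of compound 1 and differs from it in one place: dimethylamino in place of (2-(methoxycarbonyl)ethyl)amino on a carbonyl carbon. Going by the values given here, no measured pair shows what this exchange does, so any expectation rests on compound 1 alone. A moderate weakening is expected, somewhat beyond the usual scatter, as the step of a 2.6-fold higher number from compound 1 to compound 3 (0.41 log units; beyond the scatter). Compound 3 is therefore estimated to give about 8000 nM in this assay, with a range from 2500 nM to 30000 nM, and some chance that only a limit is reported.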

Compound 3, inhibition constant: > 23000 nM
Compound 3: a limit, no number; the forecaster's own chance of this, stated with the estimate: 35%; middle value at least 2.8-fold (0.45 log units) from the limit.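

The exchange matters at this place, on a carbonyl carbon whose other neighbour is a saturated ring carbon. On the core of compound 1, putting dimethylamino in place of (2-(methoxycarbonyl)ethyl)amino gives an at least 7.4-fold higher number from compound 1 to compound 3 (0.87 log units; beyond the scatter) in this assay, so the group that leaves is tied to the measurable inhibition of compound 1. That step is only a lower bound on the true change, and the full loss cannot be sized, because compound 3 reaches a limit of the assay and gives no number: the limit of > 23000 nM in this assay, at which 2 of the 3 values shown sit.

The compounds shown leave open which feature of the departing group counts, since this one exchange removes its ester, its amide hydrogen and its chain length all at once. Methylamino would restore the amide hydrogen without the ester, a plain propylamino chain would restore length without the ester, and a carboxylic acid at the end of the chain in place of the methyl ester would test that end of the group, so each of these would help to separate the features.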